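The source may report more compounds than this note shows. Statements on the series, on what has been measured and on what is new or still open speak of the compounds shown alone.

Series built on the core of compound 1 `CC(C(=O)NCc1ccc(C(F)(F)F)nc1N(C)C)c1ccc(NS(C)(=O)=O)c(F)c1`. In a functional assay on CHO-K1 cells for antagonist activity at transient receptor potential cation channel subfamily V member 1 (Homo sapiens), read by FLIPR (on this read-out higher numbers stand for weaker inhibition and lower numbers for stronger inhibition), compound 1 gives 19.1 nM. Compound 2 `CCCCN(C)c1nc(C(F)(F)F)ccc1CNC(=O)C(C)c1ccc(NS(C)(=O)=O)c(F)c1` carries propyl in place of hydrogen on a saturated chain carbon bound to a nitrogen on an aromatic ring and in this assay compound 2 gives 0.8 nM, a step of a 24-fold lower number from compound 1 to compound 2 (1.38 log units; beyond the scatter). Compound 3 `COC1CCN(c2nc(C(F)(F)F)ccc2CNC(=O)C(C)c2ccc(NS(C)(=O)=O)c(F)c2)CC1` differs from compound 1 by 4-methoxypiperidin-1-yl in place of dimethylamino on an aromatic carbon; in this assay compound 3 gives 2.4 nM, so that an 8.0-fold lower number from compound 1 to compound 3 (0.90 log units; beyond the scatter) and a 3.0-fold higher number from compound 2 to compound 3 (0.48 log units; beyond the scatter). Compound 4 `CCCCOC1CCN(c2nc(C(F)(F)F)ccc2CNC(=O)C(C)c2ccc(NS(C)(=O)=O)c(F)c2)CC1` is not yet measured and differs from compound 3 by propyl in place of hydrogen on a saturated chain carbon bound to an oxygen on a saturated carbon. This is the same kind of change as that from compound 1 to compound 2, but not the same: there the place is on a saturated chain carbon bound to a nitrogen on an aromatic ring, here on a saturated chain carbon bound to an oxygen on a saturated carbon. The expected step is a 2.0-fold lower number from compound 3 to compound 4 (0.30 log units; within the scatter), smaller than the earlier one because that step a 24-fold lower number from compound 1 to compound 2 (1.38 log units; beyond the scatter) sat at the other place and compound 3 already stands at 2.4 nM. The estimate for compound 4 is 1.2 nM, between 0.4 nM and 4 nM.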

Compound 4, inhibition constant: 3.5 nM
For compound 4 the middle estimate is 2.9-fold (0.46 log units) below the measured one, and the stated range covers the measured number.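

In this assay, propyl in place of hydrogen on the carbon bound to the oxygen, which turns methoxy into butoxy, gives a 1.5-fold higher number from compound 3 to compound 4 (0.16 log units; within the scatter), so no change can be read at this place. Set beside the step at the carbon bound to the nitrogen, the same change does not carry over with its size: the same change on two cores in this assay, a 24-fold lower number (1.38 log units; beyond the scatter) from compound 1 to compound 2 and a 1.5-fold higher number (0.16 log units; within the scatter) from compound 3 to compound 4, 35-fold (1.54 log units) apart, beyond the scatter of two such steps The two steps differ in both core and place, so these compounds do not tell which of the two accounts for the gap, and the wider steps, a 4.4-fold higher number from compound 2 to compound 4 (0.64 log units; beyond the scatter) and a 5.5-fold lower number from compound 1 to compound 4 (0.74 log units; beyond the scatter), replace the whole group on an aromatic carbon and do not settle it.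

Going by these compounds, it remains open how an ethoxy group or a chain ending in a hydroxyl or an amine would behave on the piperidine.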